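The source may report more compounds than this note shows. Statements on the series, on what has been measured and on what is new or still open speak of the compounds shown alone.

The measured compounds in an assay on Ltk cells with metabotropic glutamate receptor 5 (Homo sapiens) as the target, read by fluorescence and calcium flux; on this read-out lower numbers stand for stronger inhibition and higher numbers for weaker inhibition:
compound 1, `CCOc1cccnc1Nc1ccccn1`, gives 138 nM
compound 2, `CCOc1cccnc1Nc1cccc(C(=O)OC)n1`, gives 6200 nM
compound 3, `COc1cccnc1Nc1cccc(C)n1`, gives 458 nM

Compound 3 stands second highest of these three numbers. Its nearest neighbour is compound 1, whose number is lower by a margin beyond the scatter; its furthest is compound 2, whose number is higher, again beyond the scatter. Compound 1 and compound 3 differ in two places at once, so their two values are simply set side by side here without a step between them. Within the data shown here, the one step measured between compounds that differ in a single place is a 45-fold higher number from compound 1 to compound 2 (1.65 log units; beyond the scatter). That step, however, concerns a different group on a different carbon of the shared core and does not bear directly on the change at hand.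

Compound 4, `CCNc1cccnc1Nc1cccc(C)n1`, differs from compound 3 as follows: ethylamino in place of methoxy on an aromatic carbon. Among the measured compounds shown here, no measured pair shows what this exchange does in this assay. For the measured compounds named here, with no step to lean on, the expected shift is a 1.2-fold higher number from compound 3 to compound 4 (0.08 log units; within the scatter), not clearly beyond the scatter. Compound 4 is accordingly estimated at 550 nM, with a range from 150 nM to 2000 nM.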

Compound 4, half-maximal inhibitory concentration: 3000 nM
Compound 4: middle estimate off by 5.5-fold (0.74 log units), on the low side; measured number above the stated range.
By their numbers in this assay, from the lowest: compound 1; then compound 3; then compound 4; then compound 2.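

In this assay, the exchange of methoxy for ethylamino gives a 6.6-fold higher number from compound 3 to compound 4 (0.82 log units; beyond the scatter), so this carbon, two atoms from the ring nitrogen and ortho to a group of 8 heavy atoms, does not tolerate every small group equally. Among these compounds, until now the only single-place step concerned a different carbon of the shared core, and this is the first to show that a change at this position can move the number beyond the scatter, here in the direction of weaker inhibition. The exchange alters several things at once, with a group of 2 heavy atoms and 0 hydrogen-bond donors leaving and one of 3 heavy atoms and 1 hydrogen-bond donor entering, and nothing available here gives a reason for the step or ties it to any one of these differences.

The compounds shown leave open whether the weaker inhibition goes with the nitrogen link or with the length of the chain, a question that methylamino or a propoxy chain at this carbon would address. They also leave open how a plain amine would read here, and whether the step would be the same on the core of compound 1.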